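The source may report more compounds than this note shows. Statements on the series, on what has been measured and on what is new or still open speak of the compounds shown alone.

In a functional assay on SK-OV-3 cells (Homo sapiens) for inhibition, read by MTT assay (on this read-out lower numbers stand for stronger inhibition and higher numbers for weaker inhibition), compound 1 `COc1ccc(/C=C2\c3cc(OC)c(OC)c(OC)c3CC[C@H]2O)cc1F`, which carries a fluoro group, gives 720 nM. Compound 2 `COc1ccc(/C=C2\c3cc(OC)c(OC)c(OC)c3CC[C@H]2O)cc1[N+](=O)[O-]` reads > 10000 nM, which is a limit and not a number, so its position is known only as a limit. Compound 3 `COc1ccc(/C=C2\c3cc(OC)c(OC)c(OC)c3CC[C@H]2O)cc1C` differs from compound 2 in one place: methyl in place of nitro on an aromatic carbon. Within the data shown here, the only measured step at this place is an at least 13-fold higher number from compound 1 to compound 2 (1.14 log units; beyond the scatter), a large loss on nitro replacing fluoro. Losing nitro is therefore expected to lower the number, and the expected change is an at least 6.6-fold lower number from compound 2 to compound 3 (0.82 log units; beyond the scatter). For compound 3 the estimated value is 1500 nM, with an expected range of 400 nM to 6000 nM.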

Compound 3, half-maximal inhibitory concentration: 1340 nM
The estimate for compound 3 lay 1.1-fold (0.05 log units) above the measured number; the measured number falls inside the stated range.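

In this assay, methyl at this position does not carry the loss seen with nitro, with an at least 7.4-fold lower number from compound 2 to compound 3 (0.87 log units; beyond the scatter). The value of compound 2 is a limit and not a number: the limit of > 10000 nM in this assay, at which 1 of the 3 values shown sits. The new comparison with fluoro is a 1.9-fold higher number from compound 1 to compound 3 (0.27 log units; within the scatter), so methyl and fluoro cannot be told apart here, and among these three compounds only nitro stands out. The compounds shown leave open whether an amine or a carboxylic acid at this position would read like methyl and fluoro or like nitro.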